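This account rests on a few compounds, and the source may have more. Where it says the series, first, only, none or still open, it means among the compounds named here.

compound 1 `CCCCCCCCCCn1cc(-c2nc3ccccc3cc2CC)nn1` — > 100 ug/mL
compound 2 `CCCCCc1cc2ccccc2nc1-c1cn(CCC(F)(F)C(F)(F)C(F)(F)C(F)(F)C(F)(F)C(F)(F)C(F)(F)C(F)(F)F)nn1` — > 100 ug/mL
compound 3 `CCCCCCCCCCn1cc(-c2nc3ccccc3cc2CCCCC)nn1` — > 100 ug/mL

Each of these three values in a functional assay on COLO 205 cells (Homo sapiens) for cytotoxicity, read by MTT assay, with a stated time of 24 h (on this read-out lower numbers stand for stronger inhibition and higher numbers for weaker inhibition), is a limit of the assay, not a number. Between compound 3 and compound 1 the change is hydrogen in place of propyl on a saturated chain carbon, two bonds along the chain from an aromatic carbon, and the step that the two limits leave unreadable from compound 3 to compound 1 cannot be read, since both ends sit at the limit of > 100 ug/mL in this assay, at which 3 of the 3 values shown sit. The difference between the cores of compound 2 and compound 3 is not broken down here.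

Compound 4 `CCc1cc2ccccc2nc1-c1cn(CCC(F)(F)C(F)(F)C(F)(F)C(F)(F)C(F)(F)C(F)(F)C(F)(F)C(F)(F)F)nn1` is not yet measured in this assay. It differs from compound 2 by hydrogen in place of propyl on a saturated chain carbon, two bonds along the chain from an aromatic carbon, the same change made from compound 3 to compound 1, at the same place. The step that the limit leaves unreadable from compound 2 to compound 4 is expected to be flat, resting on a step that the two limits leave unreadable from compound 3 to compound 1 and on (the limit of > 100 ug/mL in this assay, at which 3 of the 3 values shown sit), where all three measured values sit. Compound 4 is therefore estimated at 150 ug/mL, most likely reported as a limit again, within 60 ug/mL to 500 ug/mL.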

Compound 4, half-maximal inhibitory concentration: 95.2 ug/mL
Compound 4: the middle estimate sits 1.6-fold (0.20 log units) above what was measured; the range from low to high includes it.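

In this assay, as far as these compounds go, the change of propyl to hydrogen gives an at least 1.0-fold lower number from compound 2 to compound 4 (0.02 log units; that floor lies within the scatter) and so shows no shift beyond the scatter, though the value of compound 2 is a limit and the true size of the step stays open. The same change from compound 3 to compound 1 cannot be read, because both of its ends sit at a limit: the limit of > 100 ug/mL in this assay, at which 3 of the 4 values shown sit. Whether the change carries from one core to the other therefore stays undecided, with no readable pair to set beside the step on the core of compound 2.

Still open, from the compounds shown here alone, is how an amine or a carboxylic acid in place of the ethyl group of compound 4 would read in this assay. Also open, going by these compounds, is whether a chain longer than pentyl would shift the read-out on either core.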